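The source may hold more compounds than are shown below. What is called first, only, known or untested is meant among the compounds shown, and "the series" means these compounds.

Measured in a physicochemical assay for solubility, in phosphate buffer, with a stated time of 2 h, at pH 7.4; on this read-out lower numbers stand for lower solubility and higher numbers for higher solubility:
- Compound 1 `c1ccc(-c2csc(Nc3ccc4c(c3)OCCO4)n2)nc1`: 80000 nM
- Compound 2 `COc1ccnc(-c2csc(Nc3ccc(Cl)cn3)n2)c1`: < 10000 nM
- Compound 3 `COc1ccc(-c2csc(Nc3ccc(Cl)cn3)n2)nc1`: < 10000 nM

Compound 2 stands at the limit of < 10000 nM in this assay, at which 2 of the 3 values shown sit, so its reading is a limit and not a number. Compound 1 alone gives a true number, 80000 nM.

Compound 4 `COc1ccnc(-c2nc(Nc3ccc(Cl)cn3)sc2Cl)c1` is compound 2 with one change, chloro in place of hydrogen on an aromatic carbon. Among the compounds with values here, no measured pair shows what this change does, so the expectation is cautious: no step beyond the usual scatter, in either direction. The estimated move is a step that the limit leaves unreadable from compound 2 to compound 4. A limit rather than a number is the likely report for this new compound. Compound 4 is expected at 6000 nM, with an estimated range of 2000 nM to 10000 nM.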

Compound 4, solubility: < 10000 nM
Compound 4: no number, only a limit (the forecaster's own chance of this, stated with the estimate: 85%); the middle value is on the limit's open side.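

Compound 2 and compound 4 each give only a limit, so no step can be read between them: the limit of < 10000 nM in this assay, at which 3 of the 4 values shown sit. The compounds shown leave open whether chloro in place of hydrogen on an aromatic carbon changes the reading in this assay.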